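Another Aromatic Group on the Ring Nitrogen

This account rests on a few compounds, and the source may have more. Where it says the series, first, only, none or still open, it means among the compounds named here.

Going by the values given here, in a functional assay on HCT-116 cells (Homo sapiens) for inhibition, read by sulforhodamine B assay, with a stated time of 48 h, tested at 50 uM (a lower number here means less inhibition of growth, a higher number more inhibition of growth at the concentration tested), compound 1 `COc1ccc([C@@H]2C/C(=N/OCc3cn(-c4cccc(CO)c4)nn3)c3cc(CC=C(C)C)c(OC)cc3O2)cc1` gives 27% and compound 2 `COc1ccc([C@@H]2C/C(=N/OCc3cn(-c4cc(OC)c(OC)c(OC)c4)nn3)c3cc(CC=C(C)C)c(OC)cc3O2)cc1` gives 29%, which places compound 2 level with its only measured neighbour, within the scatter. The next compound is compound 3 `COc1ccc([C@@H]2C/C(=N/OCc3cn(-c4ccc(NC(C)=O)cc4)nn3)c3cc(CC=C(C)C)c(OC)cc3O2)cc1`, which keeps the shared core and replaces a single group, with 4-acetamidophenyl in place of 3,4,5-trimethoxyphenyl on an aromatic nitrogen of a five-membered aromatic ring with 3 nitrogen. The counted difference is as follows: 4-acetamidophenyl in place of 3,4,5-trimethoxyphenyl on an aromatic nitrogen.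

Among the compounds with values here, only one measured step bears on this change, as it alters the group on the same nitrogen. That step is a number 2 percentage points higher from compound 1 to compound 2 (within the scatter), with 3,4,5-trimethoxyphenyl in place of 3-(hydroxymethyl)phenyl. Within the data shown here, this single step offers thin evidence, and no measured compound carries the 4-acetamidophenyl group, so the data suggest no direction. In this assay, no change beyond the scatter is therefore expected, and the estimated step is a number 1 percentage points lower from compound 2 to compound 3 (within the scatter). For compound 3 the expected value is 28%, with an estimated range of 14% to 42%.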

Compound 3, percent growth inhibition at one concentration: 6%
Estimate against measurement, compound 3: 22 percentage points above; the measured number lies below the stated range.
By their numbers in this assay, from the lowest: compound 3; then compounds 1 and 2 (each within the scatter of the next).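

On the aromatic nitrogen of the five-membered ring, the group carried by the shared core now makes a readable difference in this assay: a number 23 percentage points lower from compound 2 to compound 3 (beyond the scatter), and a number 21 percentage points lower from compound 1 to compound 3 (beyond the scatter). The earlier pair had shown only that 3-(hydroxymethyl)phenyl and 3,4,5-trimethoxyphenyl gave values within the scatter of each other, which could have suggested that this position tolerates any change of aromatic group, but 4-acetamidophenyl sets compound 3 apart from both. No measurement at hand bears on why the number falls with this group.

On these data alone, it remains open whether the fall belongs to the acetamide itself or to any group at that place on the phenyl ring, and a phenyl ring bearing a free amine or a carboxylic acid there, or a plain phenyl ring, would help to separate these readings. As far as these compounds go, it is also open whether the gap between compound 3 and the other two holds at other concentrations, since each value here rests on a single tested concentration in one cell line.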